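This account rests on a few compounds, and the source may have more. Where it says the series, first, only, none or still open, it means among the compounds named here.

Three measured compounds share one core. Compound 1 `Cc1nc(NC(C)C)c2cnn(-c3ccccc3)c2n1` carries a methyl and an isopropylamino group, compound 2 `CCCNc1nc(CC)nc2c1cnn2-c1ccccc1` an ethyl and a propylamino group, and compound 3 `CCc1nc(NC(C)C)c2cnn(-c3ccccc3)c2n1` an ethyl with an isopropylamino group. In a functional assay on G-361 cells (Homo sapiens) for cytotoxicity, read by sulforhodamine B assay (on this read-out lower numbers stand for higher toxicity in this test and higher numbers for lower toxicity in this test), compound 1 gives > 100000 nM, which is a limit of the assay and not a number. Compound 2 in this assay likewise returns only a limit, > 100000 nM. For compound 3 the read in this assay is also a limit, > 100000 nM. Compound 3 therefore stands together with the other two at the limit of > 100000 nM in this assay, at which 3 of the 3 values shown sit, and neither the step that the two limits leave unreadable from compound 1 to compound 3 nor the step that the two limits leave unreadable from compound 2 to compound 3 can be sized.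

Compound 4 `CCc1nc(NCc2ccco2)c2cnn(-c3ccccc3)c2n1` differs from compound 3 by (furan-2-yl)methyl in place of isopropyl on a nitrogen on an aromatic ring. The two measured steps touch the same part of the molecule, yet both are unreadable, so no step beyond the scatter can be predicted in this assay in either direction. The step of a number no higher from compound 3 to compound 4 (the limit leaves the size open) is accordingly expected to be small. Compound 4 is estimated to give about 100000 nM, within 30000 nM to 300000 nM, in this assay.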

Compound 4, concentration lethal to 50% of the cells: > 100000 nM
Compound 4: no number, only a limit; the forecaster's own chance of this, stated with the estimate: 80%; the middle value lies on the limit itself.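

Compound 4 returns only a limit in this assay, so its steps from compound 2 and compound 3 cannot be read: the limit of > 100000 nM in this assay, at which 4 of the 4 values shown sit.

The compounds shown leave open whether any of these changes on the shared core alters the read-out in this assay at all.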